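A few compounds are considered here, and "the series" means these few. Any claim that something is new, unique, unknown or untested is made for them only; others in the source may bear on it.

Compounds measured in a functional assay on L1210 (1565) cells (Mus musculus) for cytotoxicity; a higher number here means that more compound is needed for the effect, a lower number that less compound is needed:
- compound 1, `Oc1ccc2c(O)cc(-c3ccccc3)nc2c1`: 0.45 ug/mL
- compound 2, `Oc1cc(-c2ccccc2)nc2cc(F)ccc12`: 0.16 ug/mL
- compound 3, `Oc1cc(-c2ccccc2)nc2c(O)cccc12`: > 10 ug/mL

Compound 1 and compound 2 share one core and differ in a single place: fluoro in place of hydroxy on an aromatic carbon. That change gives a 2.8-fold lower number from compound 1 to compound 2 (0.45 log units; beyond the scatter). Compound 3 carries the same atoms as compound 1 joined differently; the difference between the two cores is not broken down here. For compound 3 the result in this assay is only a limit, > 10 ug/mL, not a number, and it is the one case among the three that sits at the limit of > 10 ug/mL in this assay, at which 1 of the 3 values shown sits.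

Compound 4, `Oc1cc(-c2ccccc2)nc2c(F)cccc12`, has not been measured. It stands to compound 3 as compound 2 stands to compound 1: fluoro in place of hydroxy on an aromatic carbon. The two changes are of the same kind, yet not the same, for in compound 1 the place is meta to a fused ring and para to a fused ring, while in compound 3 it is ortho to a fused ring and meta to a fused ring.

For the measured compounds named here, the only measured step of this kind is a 2.8-fold lower number from compound 1 to compound 2 (0.45 log units; beyond the scatter), and it is the sole basis for what follows. Because compound 3 gives only a limit, > 10 ug/mL, the starting point for compound 4 is itself uncertain, and the estimate for compound 4 is given a wide range. The step from compound 3 to compound 4 is expected to be an at least 2.0-fold lower number from compound 3 to compound 4 (0.30 log units; that floor lies within the scatter). In this assay compound 4 is expected at about 5 ug/mL, between 1 ug/mL and 30 ug/mL.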

Compound 4, half-maximal effective concentration: 0.57 ug/mL
The estimate for compound 4 lay 8.8-fold (0.94 log units) above the measured number, outside the stated range (below it).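

In this assay, fluoro in place of hydroxy again lowers the number on the second core, giving an at least 17-fold lower number from compound 3 to compound 4 (1.24 log units; beyond the scatter), so in both pairs shown the change runs in the same direction and beyond the scatter. The direction thus carried over from one core to the other, but the size did not, and the two steps cannot be treated as one transferable increment: the same change on two cores in this assay, a 2.8-fold lower number (0.45 log units; beyond the scatter) from compound 1 to compound 2 and an at least 17-fold lower number (1.24 log units; beyond the scatter) from compound 3 to compound 4, at least 6.2-fold (0.79 log units) apart, beyond the scatter of two such steps. For compound 3 the result is only a limit, > 10 ug/mL, so the step on its core has a floor and no upper bound, and these two pairs show neither how large that step really is nor why the two cores differ.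

The compounds shown leave open whether the same direction would hold on a third core, or with the change made at other aromatic carbons of the same two cores. They also leave open how an amine, a methoxy group or a chloro group would compare with fluoro and hydroxy in the place that is ortho to a fused ring and meta to a fused ring.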